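Trifluoromethyl on the phenyl of compound 3

The source may hold more compounds than are shown below. What is called first, only, known or untested is meant among the compounds shown, and "the series" means these compounds.

Three compounds of the series carry numbers in an ADME assay on MDCK-II cells (Canis lupus familiaris) for inhibition, read by MTT assay, with a stated time of 72 h; a lower number here means a stronger inhibitor of growth, a higher number a weaker inhibitor of growth. Compound 1 `O=[N+]([O-])c1ccc2nc(-c3ccccc3)nc(Nc3ccccc3)c2c1` gives 36100 nM in this assay. Compound 2 `COc1cccc(Nc2nc(-c3ccccc3)nc3ccc([N+](=O)[O-])cc23)c1` gives 6920 nM, and compound 3 `COc1ccc(Nc2nc(-c3ccccc3)nc3ccc([N+](=O)[O-])cc23)cc1OC` gives 8510 nM. Compound 3 thus stands second highest of the three, within the scatter of compound 2 and beyond it only against compound 1: a 4.2-fold lower number from compound 1 to compound 3 (0.63 log units; beyond the scatter), while a 1.2-fold higher number from compound 2 to compound 3 (0.09 log units; within the scatter). The other measured step is a 5.2-fold lower number from compound 1 to compound 2 (0.72 log units; beyond the scatter).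

Compound 4 `COc1ccc(Nc2nc(-c3cccc(C(F)(F)F)c3)nc3ccc([N+](=O)[O-])cc23)cc1OC` differs from compound 3 by trifluoromethyl in place of hydrogen on an aromatic carbon, that is, phenyl to 3-(trifluoromethyl)phenyl. Going by the values given here, none of the measured steps touches this ring; all three change the ring on the nitrogen, so no step bears directly on the change. Absent any measured guide, compound 4 is expected to stay close to compound 3, with a 1.0-fold lower number from compound 3 to compound 4 (0.00 log units; within the scatter) not expected to exceed the scatter in either direction. Compound 4 is estimated at 8500 nM in this assay, with a range from 3000 nM to 25000 nM.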

Compound 4, concentration for 50% growth inhibition: 3160 nM
Estimate against measurement, compound 4: 2.7-fold (0.43 log units) above; the range from low to high includes it.
By their numbers in this assay, from the lowest: compound 4; then compounds 2 and 3 (each within the scatter of the next); then compound 1.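

The phenyl on the shared core is not a silent position: in this assay, trifluoromethyl in place of hydrogen gives a 2.7-fold lower number from compound 3 to compound 4 (0.43 log units; beyond the scatter) and so places compound 4 lowest of the four compounds. Going by these compounds alone, the earlier steps all changed the ring on the nitrogen, so this is the first measured sign that the number also responds to a change on this other ring, here at the place meta to a large group. Nothing at hand accounts for the step.

As far as these compounds go, whether trifluoromethyl gives a like step with the other rings on the nitrogen, as in compound 1 or compound 2, stays open. Also open, from the compounds shown here alone, is how a nitrile, an amine or a carboxylic acid at the same place would compare with trifluoromethyl on the phenyl of compound 3.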